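A few compounds are considered here, and "the series" means these few. Any claim that something is new, unique, unknown or untested is made for them only; others in the source may bear on it.

Working notes on three compounds with a shared core, read in a functional assay on the whole organism (strain Sprague-Dawley) for inhibition, with Rattus norvegicus as the target, with a stated time of 10 min; a higher number here means that more compound is needed for the effect, a lower number that less compound is needed. Compound 1 (`Nc1ccccc1-c1ncc(C(=O)O)c(=O)[nH]1`) gives 50 mg/kg, compound 2 (`CC(C)Oc1ccccc1-c1ncc(C(=O)O)c(=O)[nH]1`) gives 0.8 mg/kg, and compound 3 (`CCCCCOc1ccccc1-c1ncc(C(=O)O)c(=O)[nH]1`) gives 3 mg/kg. Compound 3 therefore sits in the middle of the three numbers, above compound 2 and below compound 1.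

The next entry is compound 4 (`C=CCOc1ccccc1-c1ncc(C(=O)O)c(=O)[nH]1`), with allyloxy in place of the pentyloxy of compound 3: vinyl in place of butyl on a saturated chain carbon bound to an oxygen on an aromatic ring.

The most relevant measured change sits on the same oxygen, the modest step of a 3.8-fold higher number from compound 2 to compound 3 (0.57 log units; beyond the scatter). The large steps of a 63-fold lower number from compound 1 to compound 2 (1.80 log units; beyond the scatter) and a 17-fold lower number from compound 1 to compound 3 (1.22 log units; beyond the scatter) start from amino, so they show only that both oxygen-linked chains give far lower numbers than amino. No chain with a double bond has been measured, and two chains give little basis for a trend. The expectation of a lower number rests on compound 2 at 0.8 mg/kg, which also has a shorter chain than pentyl. A small step is expected, perhaps not clear of the scatter, estimated as a 2.0-fold lower number from compound 3 to compound 4 (0.30 log units; within the scatter). For compound 4 the estimated value is 1.5 mg/kg, with an expected range from 0.6 mg/kg to 4 mg/kg.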

Compound 4, dose for 50% inhibition: 0.5 mg/kg
The estimate for compound 4 lay 3.0-fold (0.48 log units) above the measured number; the whole stated range lies above it.
By their numbers in this assay, from the lowest: compounds 4 and 2 (each within the scatter of the next); then compound 3; then compound 1.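

In this assay the change from pentyl to allyl on the oxygen gives a 6.0-fold lower number from compound 3 to compound 4 (0.78 log units; beyond the scatter) and this is beyond the scatter, so a chain with a double bond can give a clearly lower number than pentyl on this oxygen. Allyl and isopropyl are not separated, with a 1.6-fold lower number from compound 2 to compound 4 (0.20 log units; within the scatter) inside the scatter, so among the three oxygen-linked chains only the pentyl of compound 3 stands apart, with a higher number than both others. Allyloxy in place of amino gives a 100-fold lower number from compound 1 to compound 4 (2.00 log units; beyond the scatter) and so joins isopropoxy and pentyloxy in giving a far lower number than amino. No measurement at hand offers an explanation for any of these steps.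

The step from compound 3 to compound 4 shortens the chain and brings in the double bond at once, so it cannot show which of the two changes matters; a saturated propyl chain on the same oxygen would separate them. As far as these compounds go, whether the number stays this low with a benzyl or methyl group on that oxygen remains open.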